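A few compounds are considered here, and "the series" means these few. Any claim that something is new, unique, unknown or untested is made for them only; others in the source may bear on it.

Measured compounds:
- compound 1, `CC1(C)O[C@@H](CO)[C@H](Cn2cc(Cn3c4c(c5ccccc53)C(=O)c3c[n+]([O-])c5ccccc5c3C4=O)nn2)O1`: 690 nM
- compound 2, `CC1(C)OCC(Cn2cc(Cn3c4c(c5ccccc53)C(=O)c3c[n+]([O-])c5ccccc5c3C4=O)nn2)O1`: 290 nM
- compound 3, `O=C1c2c[n+]([O-])c3ccccc3c2C(=O)c2c1c1ccccc1n2Cc1cn([C@H]2O[C@H](CO)[C@@H](O)[C@H]2O)nn1`: 1490 nM

In a functional assay on MCF7 cells (Homo sapiens) for cytotoxicity, read by MTT assay, with a stated time of 72 h (a lower number here means a stronger inhibitor, a higher number a weaker inhibitor), compound 3 gives the highest of the three numbers; the steps to it were a 2.2-fold higher number from compound 1 to compound 3 (0.33 log units; beyond the scatter) and a 5.1-fold higher number from compound 2 to compound 3 (0.71 log units; beyond the scatter). Compound 4, `O=C1c2c[n+]([O-])c3ccccc3c2C(=O)c2c1c1ccccc1n2Cc1cn([C@@H]2O[C@H](CO)[C@@H](O)[C@H](O)[C@H]2O)nn1`, keeps the shared core and changes only the sugar on the triazole: 3,4,5-trihydroxy-6-(hydroxymethyl)oxan-2-yl in place of 3,4-dihydroxy-5-(hydroxymethyl)oxolan-2-yl on an aromatic nitrogen. Within the data shown here, the two steps that reach compound 3 both replaced a protected group by the free ring with its hydroxyls and both raised the number modestly; no measured step moves from one free sugar to another. For compound 4 a small rise in this assay or none beyond the scatter is expected, with the estimate set as a 1.3-fold higher number from compound 3 to compound 4 (0.13 log units; within the scatter). Compound 4 is estimated at 2000 nM, range 1000 nM to 4500 nM.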

Compound 4, half-maximal inhibitory concentration: 590 nM
Estimate against measurement, compound 4: 3.4-fold (0.53 log units) above; the whole stated range lies above it.
By their numbers in this assay, from the lowest: compound 2; then compounds 4 and 1 (each within the scatter of the next); then compound 3.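

In this assay the free sugar on this aromatic nitrogen matters: 3,4,5-trihydroxy-6-(hydroxymethyl)oxan-2-yl in place of 3,4-dihydroxy-5-(hydroxymethyl)oxolan-2-yl gives a 2.5-fold lower number from compound 3 to compound 4 (0.40 log units; beyond the scatter) and shows that removing the protection does not by itself fix the number. The free six-membered ring also gives a 1.2-fold lower number from compound 1 to compound 4 (0.07 log units; within the scatter) and a 2.0-fold higher number from compound 2 to compound 4 (0.31 log units; beyond the scatter) so that only compound 2 remains clearly lower. No measurement on hand explains the difference between the two sugars.

Open, as far as these compounds go, is whether an amine or a carboxylic acid in place of a sugar hydroxyl would shift the number. Also open, from the compounds shown here alone, is what a longer chain between the sugar and the aromatic nitrogen would do.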